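The source may report more compounds than this note shows. Statements on the series, on what has been measured and on what is new or still open speak of the compounds shown alone.

Measured so far:
compound 1 `O=c1c2ccccc2[se]n1-c1nnc(-c2ccc(Br)cc2)s1` — 43300 nM
compound 2 `O=c1c2ccccc2[se]n1-c1nnc(-c2ccccc2[N+](=O)[O-])s1` — 31200 nM
compound 3 `COc1ccc(-c2nnc(-n3[se]c4ccccc4c3=O)s2)cc1` — 10000 nM

In a functional assay on MCF7 cells (Homo sapiens) for antiproliferative activity, read by CCK-8 assay, with a stated time of 48 h (on this read-out higher numbers stand for weaker inhibition and lower numbers for stronger inhibition), compound 1 gives 43300 nM, the highest of the three numbers. Compound 2 stands nearest, its value of 31200 nM lying within the scatter of compound 1, so no order between the two can be read. Compound 3 stands furthest: the exchange of the bromo for a methoxy brings a 4.3-fold lower number from compound 1 to compound 3 (0.64 log units; beyond the scatter), a modest but real step.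

Compound 4 `Cc1cccc(-c2nnc(-n3[se]c4ccccc4c3=O)s2)c1` is not yet measured in this assay. It differs from compound 1 by 3-methylphenyl in place of 4-bromophenyl on an aromatic carbon. Among the compounds with values here, the only measured step that bears on it is the one from compound 1 to compound 3, since that step also replaces the bromo on the pendant aryl ring with another small group and gave a 4.3-fold lower number from compound 1 to compound 3 (0.64 log units; beyond the scatter). Nothing measured shows how a methyl behaves here, nor whether moving the substituent to the 3-position of the phenyl matters, so the direction is taken from compound 3 but the size is kept below it. A modest step towards a lower number is therefore expected, a 1.7-fold lower number from compound 1 to compound 4 (0.24 log units; within the scatter), with a range wide enough to include no change at all. For compound 4 the estimated value is 25000 nM, expected to fall between 8000 nM and 70000 nM.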

Compound 4, half-maximal inhibitory concentration: 19900 nM
For compound 4 the middle estimate is 1.3-fold (0.10 log units) above the measured one; low and high end bracket the measured number.
By their numbers in this assay, from the lowest: compounds 3, 4, 2 and 1 (each within the scatter of the next, the first and the last beyond it).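

Here, 3-methylphenyl in place of 4-bromophenyl gives a 2.2-fold lower number from compound 1 to compound 4 (0.34 log units; beyond the scatter) in this assay, so a lower number at this position is not tied to the methoxy of compound 3; a group with only carbon in it does the same. Both groups keep the same count of heavy atoms, and neither carries a hydrogen-bond donor or acceptor, so the two replacements of 4-bromophenyl now point the same way, while compound 3 and compound 4 lie within the scatter of each other and no order between them can be read. No measured evidence bears on the cause of this step.

The change in compound 4 removes the bromine and moves the substituent on the phenyl ring at once, so the compounds shown do not tell which of the two carries the step. They also leave open whether an amine, a carboxylic acid or a longer alkyl chain on that phenyl ring would continue the trend towards lower numbers or reverse it, and whether the bare phenyl ring would already match compound 4.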